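The source may report more compounds than this note shows. Statements on the series, on what has been measured and on what is new or still open speak of the compounds shown alone.

Compound 1 `COc1cc(/C=C/C(=O)c2cccc(-n3cc(-c4ccccc4)[nH]c3=O)c2)ccc1O` in a functional assay on HCT-116 cells (Homo sapiens) for inhibition (on this read-out higher numbers stand for weaker inhibition of growth and lower numbers for stronger inhibition of growth), gives 1400 nM; compound 2 `O=C(/C=C/c1cccc(O)c1)c1cccc(-n2cc(-c3ccccc3)[nH]c2=O)c1` gives 3020 nM in this assay. For the measured compounds named here, the one measured step, a 2.2-fold higher number from compound 1 to compound 2 (0.33 log units; beyond the scatter), changes the chain-borne ring and leaves compound 2 with the highest of the two numbers. Going by the values given here, compound 3 `O=C(/C=C/c1cccc(O)c1)c1cccc(-n2cc(-c3ccc(Cl)cc3)[nH]c2=O)c1` carries chloro in place of hydrogen on an aromatic carbon, para to a large group, on the phenyl of the shared core; no measured step touches that ring, so the only step available does not bear on this change. A step within the scatter is therefore expected, with a 1.0-fold lower number from compound 2 to compound 3 (0.00 log units; within the scatter). For compound 3 the estimate in this assay is 3000 nM, within 1200 nM to 7500 nM.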

Compound 3, concentration for 50% growth inhibition: 1230 nM
Estimate against measurement, compound 3: 2.4-fold (0.39 log units) above; measured number inside the range.
By their numbers in this assay, from the lowest: compounds 3 and 1 (each within the scatter of the next); then compound 2.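

The phenyl of the shared core is not a silent position in this assay: chloro in place of hydrogen, para to a large group, gives a 2.5-fold lower number from compound 2 to compound 3 (0.39 log units; beyond the scatter). For the compounds shown here, the earlier step showed only that the chain-borne ring matters; this one shows that the other end of the series also moves the read-out, by a modest step beyond the scatter. No measurement at hand gives a reason for this step.

The chloro is shown only with the 3-hydroxyphenyl on the chain, and whether it acts the same way with the 4-hydroxy-3-methoxyphenyl of compound 1 stays open. Also open, as far as these compounds go, is how a fluoro, a methoxy or an amine would read at this place.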